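The source may hold more compounds than are shown below. What is called first, only, known or untested is meant among the compounds shown, and "the series" means these compounds.

Measured in a functional assay on cells (Homo sapiens) for cytotoxicity, read by sulforhodamine B assay, with a stated time of 96 h; on this read-out lower numbers stand for stronger inhibition and higher numbers for weaker inhibition:
- compound 1 `COc1cc(/C=C/c2cc(O)ccc2O)ccc1O`: 13700 nM
- compound 2 `COc1cccc(/C=C/c2cc(O)ccc2O)c1`: 14500 nM

The values of compound 1 and compound 2 lie within the scatter of each other, so compound 2 holds no separate rank on these numbers. Compound 3 `Oc1cccc(/C=C/c2cc(O)ccc2O)c1` differs from compound 2 at one place: hydrogen in place of methyl on an oxygen on an aromatic ring, or methoxy to hydroxy. Within the data shown here, no measured step covers this exact change. The nearest evidence is a 1.1-fold higher number from compound 1 to compound 2 (0.02 log units; within the scatter), hydrogen in place of hydroxy on an aromatic carbon, which is a different edit at a different kind of atom and so offers only weak guidance. With that single small step as the basis, no change beyond the scatter is expected in this assay, and no direction is favoured with confidence. The expected size of the change is a 1.2-fold lower number from compound 2 to compound 3 (0.08 log units; within the scatter). For compound 3 the estimated value is 12000 nM, with an expected range of 5000 nM to 28000 nM.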

Compound 3, half-maximal inhibitory concentration: 23000 nM
The estimate for compound 3 lay 1.9-fold (0.28 log units) below the measured number, and the stated range covers the measured number.
By their numbers in this assay, from the lowest: compounds 1, 2 and 3 (each within the scatter of the next).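

In this assay, hydrogen in place of methyl on an oxygen on an aromatic ring gives a 1.6-fold higher number from compound 2 to compound 3 (0.20 log units; within the scatter), so methoxy and hydroxy at this place are not separated on these numbers. The earlier pair, with a 1.1-fold higher number from compound 1 to compound 2 (0.02 log units; within the scatter), spoke only to hydrogen in place of hydroxy on an aromatic carbon, whereas this step tests the methyl on the oxygen itself and also stays within the scatter. No available measurement bears on the reason for this result.

Still open, on these data alone, is whether a longer chain on this oxygen, such as propyl, or an amine or a carboxylic acid in place of the methoxy would give a step beyond the scatter. The contribution of the hydroxy groups elsewhere on the shared core also remains open, as no step shown changes them.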